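The compounds below may be only part of what the source reports. "The series", "measured", "known", "first", "only" and "open" are said of these compounds alone.

Within the data shown here, the series so far holds two measured compounds. In a functional assay on KB 3-1 cells (Homo sapiens) for cytotoxicity, read by MTT assay, with a stated time of 72 h (on this read-out lower numbers stand for stronger inhibition and higher numbers for weaker inhibition), compound 1 (`O=C1Nc2ccccc2/C1=N/NC(=S)Nc1ccccc1`) gives 3530 nM as its value, and compound 2 (`C=CCNC(=S)N/N=C1\C(=O)Nc2ccccc21`) gives 26100 nM as the higher of the two numbers. Compound 3 (`CNC(=S)N/N=C1\C(=O)Nc2ccccc21`), not yet measured, follows from compound 2 by hydrogen in place of vinyl on a saturated chain carbon bound to an amide-type nitrogen, which reads as allyl to methyl. Among the measured compounds shown here, only one measured step bears on this, a 7.4-fold higher number from compound 1 to compound 2 (0.87 log units; beyond the scatter) with allyl in place of phenyl on an amide-type nitrogen. For the measured compounds named here, that step is a different exchange, and no measured pair covers allyl to methyl, so it gives only a weak guide to direction. In this assay a slight rise in the number is expected, not clearly beyond the scatter. The estimate amounts to a 1.5-fold higher number from compound 2 to compound 3 (0.19 log units; within the scatter) as the expected step. For compound 3 the estimated value is 40000 nM with an expected range of 13000 nM to 110000 nM on this basis.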

Compound 3, half-maximal inhibitory concentration: 35300 nM
Compound 3: middle estimate off by 1.1-fold (0.05 log units), on the high side; the range from low to high includes it.
By their numbers in this assay, from the lowest: compound 1; then compounds 2 and 3 (each within the scatter of the next).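

In this assay, hydrogen in place of vinyl on a saturated chain carbon bound to an amide-type nitrogen comes out as (a 1.4-fold higher number from compound 2 to compound 3 (0.13 log units; within the scatter)), so the allyl and methyl groups are not told apart at this position. Phenyl now stands apart from both small chains: with methyl in its place on the amide-type nitrogen, the step is (a 10-fold higher number from compound 1 to compound 3 (1.00 log units; beyond the scatter)), and with allyl in its place it is (a 7.4-fold higher number from compound 1 to compound 2 (0.87 log units; beyond the scatter)). The data hold nothing that explains these numbers.

From the compounds shown here alone, it remains open whether the aromatic ring itself separates compound 1 from compound 2 and compound 3, or whether any larger group on that nitrogen would do the same. A cyclohexyl or benzyl group there would help separate these readings, and a chlorophenyl group would show how far the phenyl ring tolerates substitution.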